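Methoxy to hydroxy from compound 3 to compound 4

This account rests on a few compounds, and the source may have more. Where it says the series, first, only, none or still open, it means among the compounds named here.

In a functional assay on HL-60 cells (Homo sapiens) for cytotoxicity (on this read-out higher numbers stand for weaker inhibition and lower numbers for stronger inhibition), compound 1 (`COc1c(O)cc2c3c1C[C@@H](C)C[C@H](OC)[C@H](O3)[C@@H](C)/C=C(\C)[C@H](OC(N)=O)[C@@H](OC)CC/C=C(\C)C(=O)N2`) gives 86000 nM and compound 2 (`COc1c(O)cc2c3c1C[C@@H](C)C[C@H](OC)[C@H](O3)[C@@H](C)/C=C(\C)[C@H](OC(N)=O)[C@@H](OC)/C=C\C=C(\C)C(=O)N2`) gives 48000 nM in the same read-out; these two values lie within the usual scatter of each other. Compound 3 (`COc1c(O)cc2cc1C[C@@H](C)C[C@H](OC)[C@H](O)[C@@H](C)/C=C(\C)[C@H](OC(N)=O)[C@@H](OC)CC/C=C(\C)C(=O)N2`) has no place on this numerical scale: in this assay compound 3 is recorded as "not active" (no number reported) with no number reported.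

Compound 4 (`CO[C@H]1C[C@H](C)Cc2cc(cc(O)c2O)NC(=O)/C(C)=C/CC[C@H](OC)[C@@H](OC(N)=O)/C(C)=C/[C@H](C)[C@H]1O`) comes from compound 3 through a single change (hydrogen in place of methyl on an oxygen on an aromatic ring) that puts hydrogen in place of methyl on an oxygen on an aromatic ring, so methoxy to hydroxy. Among the measured compounds shown here, no measured pair shows this change, and the data offer no direct precedent for it. Without a number for compound 3, the step cannot be sized as a ratio. The expectation is a modest move towards stronger inhibition, into the region marked by compound 2 at 48000 nM and by compound 1 at 86000 nM in the series. A second reading without a number remains possible. In this assay the estimated value for compound 4 is 30000 nM (expected range 3000 nM to 100000 nM).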

Compound 4, half-maximal inhibitory concentration: "not active" (no number reported)
Compound 4 has no reported number here; there is nothing to compare the estimate with.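

In this assay compound 3 and compound 4 both carry the entry "not active" with no number, so no step can be read between them. Nothing shown here bears on this result. The compounds shown leave open whether methoxy to hydroxy changes inhibition in any compound with a numerical reading.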